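The compounds below may be only part of what the source reports. "The series", "measured", "known", "first", "only" and "open" are said of these compounds alone.

Measured compounds and their values:

Compound 1, `O=C(Nc1ccccc1)C(Cl)Cl`, gives 130000 nM.
Compound 2, `O=C(Nc1cccc(Br)c1)C(Cl)Cl`, gives 7800 nM.
Compound 3, `O=C(Nc1cccc([N+](=O)[O-])c1)C(Cl)Cl`, gives 18000 nM.

These three share one core, a dichloroacetamide attached to a benzene ring, and differ only in what sits on that ring. In a functional assay on A549 cells (Homo sapiens) for antiproliferative activity, read by MTT assay, with a stated time of 72 h (on this read-out lower numbers stand for stronger inhibition and higher numbers for weaker inhibition), compound 3 stands second highest of the three numbers: compound 2 lies nearest, with a 2.3-fold higher number from compound 2 to compound 3 (0.36 log units; beyond the scatter), while compound 1 lies furthest, with a 7.2-fold lower number from compound 1 to compound 3 (0.86 log units; beyond the scatter). The next compound, compound 4, `O=C(Nc1cccc(C(F)(F)F)c1)C(Cl)Cl`, carries trifluoromethyl in place of nitro on an aromatic carbon. Going by the values given here, three measured steps bear on this change: a 17-fold lower number from compound 1 to compound 2 (1.22 log units; beyond the scatter) and a 7.2-fold lower number from compound 1 to compound 3 (0.86 log units; beyond the scatter) show that either substituent lowers the number strongly against the bare ring, and a 2.3-fold higher number from compound 2 to compound 3 (0.36 log units; beyond the scatter) shows that swapping one substituent for the other changes the number only modestly. A further swap of substituent is therefore expected to move this assay by a modest step, most likely downward toward compound 2. Compound 4 is thus estimated at 9000 nM, within a range from 3000 nM to 27000 nM, which means an expected step of a 2.0-fold lower number from compound 3 to compound 4 (0.30 log units; within the scatter).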

Compound 4, half-maximal inhibitory concentration: 12200 nM
For compound 4 the middle estimate is 1.4-fold (0.13 log units) below the measured one, within the range that was stated.
By their numbers in this assay, from the lowest: compounds 2, 4 and 3 (each within the scatter of the next, the first and the last beyond it); then compound 1.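

In this assay, trifluoromethyl in place of hydrogen brings an 11-fold lower number from compound 1 to compound 4 (1.03 log units; beyond the scatter) and so shows that a third kind of group at this place also stands clearly apart from the unsubstituted ring. Swapping in trifluoromethyl for either earlier group is a different matter: a 1.5-fold lower number from compound 3 to compound 4 (0.17 log units; within the scatter) and a 1.6-fold higher number from compound 2 to compound 4 (0.19 log units; within the scatter) both lie within the scatter, so compound 4 cannot be told apart from compound 2 or compound 3 on this read-out. No measurement of any property of these groups is available to explain why they fall so close together.

The compounds shown leave open how this place responds to an amine, a carboxylic acid or a longer chain. They also leave open whether trifluoromethyl would give a similar number on a different carbon of the ring.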